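This account rests on a few compounds, and the source may have more. Where it says the series, first, only, none or still open, it means among the compounds named here.

In a physicochemical assay for solubility, read by HPLC, in phosphate buffer, with a stated time of 24 h, at pH 7.4, tested at 100 uM (on this read-out lower numbers stand for lower solubility and higher numbers for higher solubility), compound 1 (`COc1ccc(Nc2c(NCCCCCC(=O)NO)c(=O)c2=O)cc1`) gives 3300000 nM, compound 2 (`CC(CCCCC(=O)NO)Nc1c(Nc2ccccc2)c(=O)c1=O`) gives 93000000 nM, and compound 3 (`COc1ccc(Nc2c(NC(C)CCCCC(=O)NO)c(=O)c2=O)cc1`) gives 85000000 nM. Compound 3 therefore stands level with compound 2 and far from compound 1. Compound 4 (`COc1ccc(Nc2c(NC(C)(C)CCCCC(=O)NO)c(=O)c2=O)cc1`) differs from compound 3 by a single change: methyl in place of hydrogen on a saturated chain carbon bound to a nitrogen on an aromatic ring and two saturated chain carbons. Within the data shown here, the closest precedent is the methyl added at this same chain carbon, a 26-fold higher number from compound 1 to compound 3 (1.41 log units; beyond the scatter), a large step beyond the scatter. The methoxy step, a 1.1-fold lower number from compound 2 to compound 3 (0.04 log units; within the scatter), lies within the scatter and concerns an aromatic carbon, so it bears on this change only weakly. A single precedent cannot show that a second methyl on that carbon would repeat the large step. In this assay, no change beyond the scatter is therefore expected, and the estimated step is a 1.1-fold higher number from compound 3 to compound 4 (0.02 log units; within the scatter). Compound 4 is estimated at 90000000 nM, with an expected range from 35000000 nM to 200000000 nM.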

Compound 4, solubility: 99000000 nM
For compound 4 the middle estimate is 1.1-fold (0.04 log units) below the measured one, within the range that was stated.
By their numbers in this assay, from the lowest: compound 1; then compounds 3, 2 and 4 (each within the scatter of the next).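

In this assay, a second methyl on the saturated chain carbon bound to a nitrogen on an aromatic ring and two saturated chain carbons gives a 1.2-fold higher number from compound 3 to compound 4 (0.07 log units; within the scatter). The large step seen when a methyl was placed on this chain carbon, a 26-fold higher number from compound 1 to compound 3 (1.41 log units; beyond the scatter), therefore does not recur with the next methyl, and compound 3 and compound 4, which carry one and two methyl groups there, stand within the scatter of each other. Nothing in the data gives a reason for either step.

The compounds shown leave open whether an ethyl group, an amine or a carboxylic acid on that same carbon would keep the number level with compound 3. They also leave open whether the second methyl would give the same small step without the methoxy group on the aromatic carbon.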